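A few compounds are considered here, and "the series" means these few. Any claim that something is new, unique, unknown or untested is made for them only; others in the source may bear on it.

Compound 1, `COc1cc(NC(=O)c2cc(NC(=O)C(C)Br)ccc2F)cc(OC)c1OC`, and compound 2, `COc1ccc(NC(=O)c2cc(NC(=O)C(C)Br)ccc2F)cc1`, share a core in which a fluorinated benzamide carries a 2-bromopropanamide on one side and an anilide on the other. In a functional assay on PC-3 cells (Homo sapiens) for antiproliferative activity (a lower number here means a stronger inhibitor, a higher number a weaker inhibitor), compound 1 gives 2180 nM. In this assay compound 2 gives 2430 nM. Compound 2 stands alongside compound 1 on these two numbers: the gap between them is within the scatter of repeated measurements, so neither can be called the stronger or the weaker of the pair.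

Compound 3, `COc1cc(NC(=O)c2cc(NC(=O)C(C)Br)ccc2F)ccn1`, differs from compound 2 in one place: 2-methoxypyridin-4-yl in place of 4-methoxyphenyl on an amide-type nitrogen. Among the measured compounds shown here, no step between two measured compounds of this set bears on such an exchange, so there is no measured guide to its effect. Compound 3 is therefore expected to land close to compound 2, with the step from compound 2 to compound 3 expected to be a 1.0-fold higher number from compound 2 to compound 3 (0.01 log units; within the scatter), that is, no change beyond the scatter in either direction. The estimate for compound 3 in this assay is 2500 nM, with a range from 1200 nM to 5500 nM.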

Compound 3, half-maximal inhibitory concentration: 2420 nM
Beside the measured number, compound 3's estimate is 1.0-fold (0.01 log units) above it; measured number inside the range.
By their numbers in this assay, from the lowest: compounds 1, 3 and 2 (each within the scatter of the next).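

In this assay, among the compounds shown here, putting 2-methoxypyridin-4-yl in place of 4-methoxyphenyl on an amide-type nitrogen gives a 1.0-fold lower number from compound 2 to compound 3 (0.00 log units; within the scatter), and this is the first measured step at this position in the set. The exchange of a ring carbon for a ring nitrogen, which adds one hydrogen-bond acceptor to the count for the group, therefore leaves the two compounds indistinguishable in this assay, so at least this one nitrogen-containing ring is accepted here without a difference beyond the scatter. For the compounds shown here, nothing available accounts for why the two groups read alike, and the single step cannot show whether that would hold on another core.

The compounds shown leave open how far this position accepts groups of other kinds, such as a piperidine ring or a phenyl ring bearing a carboxylic acid, or an amine in place of the methoxy group. They also leave open what part the 2-bromopropanamide plays, since it is the same in all three compounds and no chloroacetamide or plain propanamide stands beside it for comparison.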